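A few compounds are considered here, and "the series" means these few. Any claim that something is new, unique, unknown or untested is made for them only; others in the source may bear on it.

For the measured compounds named here, in a functional assay on FM3A cells (Mus musculus) for antiproliferative activity, with a stated time of 48 h (on this read-out higher numbers stand for weaker inhibition and lower numbers for stronger inhibition), compound 1 (`C=C(Br)C(=O)Nc1ccc(C(=O)/C=C/c2cccc(OC)c2)cc1`) gives 1800 nM, the highest of the three numbers so far. Compound 2 (`C=C(Br)C(=O)Nc1ccc(C(=O)/C=C/c2ccccc2OC)cc1`) gives 370 nM, and compound 3 (`C=C(Br)C(=O)Nc1ccc(C(=O)/C=C/c2cccc(OC)c2OC)cc1`) gives 550 nM. Compound 4 (`COc1cccc(/C=C/C(=O)c2ccc(N)cc2)c1`) is unmeasured and differs from compound 1 as follows: hydrogen in place of (1-bromoethenyl)carbonyl on a nitrogen on an aromatic ring. In words, this is hydrogen in place of (1-bromoethenyl)carbonyl on a nitrogen on an aromatic ring. The measured steps all concern methoxy groups: a 4.9-fold lower number from compound 1 to compound 2 (0.69 log units; beyond the scatter), a 3.3-fold lower number from compound 1 to compound 3 (0.51 log units; beyond the scatter) and a 1.5-fold higher number from compound 2 to compound 3 (0.17 log units; within the scatter). Going by the values given here, none of them touches the (1-bromoethenyl)carbonyl group, so they bear only indirectly and no direct precedent exists. With so much of the structure removed, a move to a higher number is expected, larger than a 4.9-fold lower number from compound 1 to compound 2 (0.69 log units; beyond the scatter). The expected change is an 8.3-fold higher number from compound 1 to compound 4 (0.92 log units; beyond the scatter). Compound 4 is estimated at 15000 nM, with a range of 4000 nM to 60000 nM.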

Compound 4, half-maximal inhibitory concentration: 45000 nM
The estimate for compound 4 lay 3.0-fold (0.48 log units) below the measured number; the measured number falls inside the stated range.
By their numbers in this assay, from the lowest: compounds 2 and 3 (each within the scatter of the next); then compound 1; then compound 4.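

For the compounds shown here, the step at this nitrogen, a 25-fold higher number from compound 1 to compound 4 (1.40 log units; beyond the scatter) in this assay, is the first change away from the methoxy groups, and it is larger than any methoxy step. Within this pair, the number therefore depends strongly on keeping the (1-bromoethenyl)carbonyl group, although the amino compound still gives a finite value. Nothing available explains the size of this step.

Open, on these data alone, is which part of the group matters: an acetyl or a propenoyl group on the same nitrogen would separate the carbonyl, double bond and bromine. Also open, as far as these compounds go, is whether the step recurs with the methoxy pattern of compound 2.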